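This account rests on a few compounds, and the source may have more. Where it says the series, first, only, none or still open, it means among the compounds named here.

Three compounds in this set share one core. Compound 1 `COc1ccc(-c2cc(/C=C/C(=O)c3ccc(N)cc3)[nH]n2)cc1` gives 2120 nM in a functional assay on 786-0 cells (Homo sapiens) for inhibition, read by sulforhodamine B assay, with a stated time of 48 h; a lower number here means a stronger inhibitor of growth, a higher number a weaker inhibitor of growth. Compound 2 `COc1cc(-c2cc(/C=C/C(=O)c3ccc(N)cc3)[nH]n2)cc(OC)c1OC` gives 2040 nM in this assay, and compound 3 `COc1ccc(C(=O)/C=C/c2cc(-c3cc(OC)c(OC)c(OC)c3)n[nH]2)cc1` gives 1950 nM. Going by the values given here, compound 2 stands second highest of the three numbers, its nearest neighbour being compound 1 and its furthest compound 3, both within the scatter; the one single-point step, a 1.0-fold lower number from compound 2 to compound 3 (0.02 log units; within the scatter), is likewise within the scatter. Compound 4 `COc1ccc(-c2cc(/C=C/C(=O)c3ccc(N)cc3)[nH]n2)cc1OC` differs from compound 2 by hydrogen in place of methoxy on an aromatic carbon. Among the compounds with values here, no measured step removes a methoxy from that ring, so nothing bears on it directly, and with all three numbers within the scatter of one another the step from compound 2 to compound 4 is expected to be small, a 1.0-fold higher number from compound 2 to compound 4 (0.01 log units; within the scatter). Compound 4 is therefore estimated at 2100 nM, within 1000 nM to 4500 nM.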

Compound 4, concentration for 50% growth inhibition: 1880 nM
Estimate against measurement, compound 4: 1.1-fold (0.05 log units) above, within the range that was stated.
By their numbers in this assay, from the lowest: compounds 4, 3, 2 and 1 (each within the scatter of the next).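

On the ring that carries the methoxy groups, hydrogen in place of a methoxy ortho to a methoxy group gives a 1.1-fold lower number from compound 2 to compound 4 (0.04 log units; within the scatter) in this assay and, going the other way, methoxy in place of hydrogen gives a 1.1-fold lower number from compound 1 to compound 4 (0.05 log units; within the scatter) on the same ring. Going by these compounds alone, these are the first steps that change the methoxy groups on this ring, and both stay within the scatter. Nothing given here offers a reason for this. The compounds shown carry only hydrogen or methoxy at this position, so a hydroxyl, a chlorine or a longer ether chain there remains open.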